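From 4-methoxyphenyl to phenethyl on a sulfur

The source may report more compounds than this note shows. Statements on the series, on what has been measured and on what is new or still open speak of the compounds shown alone.

Values in a functional assay on SMMC-7721 cells (Homo sapiens) for inhibition, read by CCK-8 assay, with a stated time of 72 h, tested at 2 uM (a higher number here means more inhibition of growth at the concentration tested, a lower number less inhibition of growth), are as follows.
- Compound 1 `COc1ccc(SCc2ccc(C(=O)Nc3ccccc3N)cc2)cc1` gives 33.1%
- Compound 2 `Nc1ccccc1NC(=O)/C=C/c1ccc(CSc2ccc(C(F)(F)F)cn2)cc1` gives 12.1%
- Compound 3 `COc1ccc(SCc2ccc(C(=O)Nc3ccccc3N)cc2)cc1OC` gives 20.2%

Compound 1 stands highest of the three in this assay and both others lie below it beyond the scatter. The change to compound 4 `Nc1ccccc1NC(=O)c1ccc(CSCCc2ccccc2)cc1` is phenethyl in place of 4-methoxyphenyl on a sulfur and amounts to phenethyl in place of 4-methoxyphenyl on a sulfur. Going by the values given here, only one measured step bears on it, the modest a number 12.9 percentage points lower from compound 1 to compound 3 (beyond the scatter) on adding methoxy in place of hydrogen on an aromatic carbon. Among the compounds with values here, no measured compound carries phenethyl, so the guide is loose. A modest downward step of similar size is expected in this assay and the estimate is a number 9.1 percentage points lower from compound 1 to compound 4 (within the scatter) with wide uncertainty. For compound 4 the estimated value is 24% with an expected range from 8% to 40% around it.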

Compound 4, percent growth inhibition at one concentration: 28.1%
Beside the measured number, compound 4's estimate is 4.1 percentage points below it; the measured number falls inside the stated range.
By their numbers in this assay, from the lowest: compounds 2, 3, 4 and 1 (each within the scatter of the next, the first and the last beyond it).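

In this assay, phenethyl replaces 4-methoxyphenyl on the sulfur with a number 5 percentage points lower from compound 1 to compound 4 (within the scatter). Going by these compounds alone, this shows that the position tolerates a group without oxygen, and that the entering group's aromatic ring need not be the one in compound 1, without a change beyond the scatter. No measurement here offers a reason for this result. From the compounds shown here alone, it remains open whether a shorter benzyl group, a longer phenylpropyl chain or an amine on the sulfur would give a value like that of compound 4. Whether phenethyl would act alike on the core of compound 2 is also unresolved.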